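The source may report more compounds than this note shows. Statements on the series, on what has been measured and on what is new or still open speak of the compounds shown alone.

Measured so far in an assay on cells for inhibition of Polyunsaturated fatty acid 5-lipoxygenase (Rattus norvegicus); a higher number here means a weaker inhibitor, a lower number a stronger inhibitor:

Compound 2, `COc1ccc2[nH]c(C)c(CCCC(=O)N3CCOCC3)c2c1`: 3160 nM
Compound 1, `COc1ccc2c(c1)c(CCCC(=O)N1CCOCC1)c(C)n2C(=O)c1ccc(Cl)cc1`: 2250 nM

Compound 2 and compound 1 share one core and differ only at the ring nitrogen, where compound 2 carries a hydrogen in place of the (4-chlorophenyl)carbonyl of compound 1. Within the data shown here, the step of a 1.4-fold higher number from compound 1 to compound 2 (0.15 log units; within the scatter) is within the scatter, so the two numbers are best read as one level; compound 2 stands on that level, with compound 1 as its only neighbour.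

Compound 3, `Cc1[nH]c2ccc(Cl)cc2c1CCCC(=O)N1CCOCC1`, is the next member. Compared with compound 2 it shows (chloro in place of methoxy on an aromatic carbon). Among the measured compounds shown here, no measured step touches this position: the only step in hand, a 1.4-fold higher number from compound 1 to compound 2 (0.15 log units; within the scatter), concerns the ring nitrogen and says nothing about the methoxy. In this assay, for the measured compounds named here, the change therefore has no measured precedent, and the expectation has to be a broad one centred near the level of compound 2.

Compound 3 is thus expected to give about 3500 nM in this assay, within a range from 1200 nM to 10000 nM. The expected step of a 1.1-fold higher number from compound 2 to compound 3 (0.04 log units; within the scatter) is one that may not rise above the scatter.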

Compound 3, half-maximal inhibitory concentration: 1330 nM
Compound 3: middle estimate off by 2.6-fold (0.42 log units), on the high side; the range from low to high includes it.
By their numbers in this assay, from the lowest: compounds 3, 1 and 2 (each within the scatter of the next, the first and the last beyond it).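

In this assay, the aromatic carbon that carries the methoxy turns out to be a place where a single swap registers: chloro in place of methoxy gives a 2.4-fold lower number from compound 2 to compound 3 (0.38 log units; beyond the scatter), a modest step but one beyond the scatter, unlike the change at the ring nitrogen, a 1.4-fold higher number from compound 1 to compound 2 (0.15 log units; within the scatter). In this pair the methoxy, with its hydrogen-bond acceptor and its extra heavy atom, is not needed to hold the level of compound 2, as the number falls rather than rises when chloro takes its place. Nothing measured on these compounds bears on why the number moves at this carbon.

As far as these compounds go, it remains open whether the lower number belongs to the chloro itself or simply to the loss of the methoxy, a question that a bare hydrogen, a fluoro or a trifluoromethyl at the same carbon would help to settle. From the compounds shown here alone, it is also open whether the step carries over to compounds with the (4-chlorophenyl)carbonyl on the ring nitrogen, or with a carboxylic acid in place of the amide at the end of the chain.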